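A few compounds are considered here, and "the series" means these few. Any claim that something is new, unique, unknown or untested is made for them only; others in the source may bear on it.

Measured in a functional assay on HCT-15 cells (Homo sapiens) for inhibition, read by sulforhodamine B assay; a lower number here means a stronger inhibitor of growth, a higher number a weaker inhibitor of growth:
- compound 1 `CC(=O)Nc1ccc(CN2CCC=C(CCC(=O)NO)C2=O)cc1`: "not determined" (no result reported)
- compound 2 `COc1ccc(CN2CCC=C(CCC(=O)NO)C2=O)cc1`: 6890 nM
- compound 3 `Cc1ccc(S(=O)(=O)Nc2ccc(CN3CCC=C(CCC(=O)NO)C3=O)cc2)cc1`: > 10000 nM

Among these three entries, compound 2 alone has an actual number, 6890 nM. Compound 1 has no result to set beside it. For compound 3, the entry > 10000 nM is a limit of the assay and not a number. Compound 2 therefore stands as the single firm reference point in this assay.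

Compound 4 `O=C(CCC1=CCCN(Cc2ccc(Br)cc2)C1=O)NO` keeps the shared core of compound 2 and has bromo in place of methoxy on an aromatic carbon, para to a large group (bromo in place of methoxy on an aromatic carbon). Among the measured compounds shown here, no pair of measured compounds differs in one place only, so no measured step can serve as a guide. The reasoning rests on compound 2 at 6890 nM, and a swap of one small group is expected to move the value only modestly. The expected change, a 1.4-fold lower number from compound 2 to compound 4 (0.14 log units; within the scatter), leans slightly towards stronger inhibition of growth and may not exceed the usual scatter. For compound 4 the estimated value is 5000 nM, with an expected range of 2000 nM to 10000 nM.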

Compound 4, concentration for 50% growth inhibition: 1720 nM
Estimate against measurement, compound 4: 2.9-fold (0.46 log units) above; the whole stated range lies above it.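

In this assay, a 4.0-fold lower number from compound 2 to compound 4 (0.60 log units; beyond the scatter) gives the series its first measured step, and that step lies beyond the usual scatter. It shows that the aromatic carbon para to a large group is not a silent place: exchanging methoxy for bromo, a single small group for another, is enough to change growth inhibition. Nothing given here accounts for the direction or size of this step.

The compounds shown leave open how other groups at this same carbon, such as chloro, nitrile or an amine, would compare with bromo. With a single step to go on, they also leave open whether a longer chain on the shared core would alter the effect of this change.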